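A few compounds are considered here, and "the series" means these few. Any claim that something is new, unique, unknown or untested is made for them only; others in the source may bear on it.

Compound 1 `COc1cc(-c2nn(-c3cccc(NC(=O)c4cccc(C(F)(F)F)c4)c3)cc2-c2ccncc2)ccc1Cl` gives 2460 nM in a functional assay on SNB-19 cells (Homo sapiens) for inhibition, read by sulforhodamine B assay, with a stated time of 48 h; a higher number here means a weaker inhibitor of growth, a lower number a stronger inhibitor of growth. Compound 2 `COc1cc(-c2nn(-c3cccc(NC(=O)Nc4ccc(Cl)c(Cl)c4)c3)cc2-c2ccncc2)ccc1Cl` gives 1720 nM. Compound 3 `COc1cc(-c2nn(-c3cccc(NC(=O)c4ccc(Cl)c(C(F)(F)F)c4)c3)cc2-c2ccncc2)ccc1Cl` gives 8680 nM.

Compound 3 stands highest of the three numbers: there is a 3.5-fold higher number from compound 1 to compound 3 (0.55 log units; beyond the scatter) and a 5.0-fold higher number from compound 2 to compound 3 (0.70 log units; beyond the scatter), both beyond the scatter, so compound 3 is the weakest inhibitor of growth among the measured set. Compound 4 `COc1cc(-c2nn(-c3cccc(NC(=O)Nc4ccc(Cl)c(C(F)(F)F)c4)c3)cc2-c2ccncc2)ccc1Cl` differs from compound 3 in one place: (4-chloro-3-(trifluoromethyl)phenyl)amino in place of 4-chloro-3-(trifluoromethyl)phenyl on a carbonyl carbon. Within the data shown here, one measured step bears directly on this kind of exchange, the one from the carbonyl-bound aryl to an arylamino, namely a 1.4-fold lower number from compound 1 to compound 2 (0.16 log units; within the scatter), which lies within the scatter. Among the measured compounds shown here, no measured pair shows this exchange on the 4-chloro-3-(trifluoromethyl)phenyl group itself. On that basis, a step of about a 1.3-fold lower number from compound 3 to compound 4 (0.13 log units; within the scatter) is expected in this assay, a small lowering that may well fall inside the scatter. For compound 4 the estimate in this assay is 6500 nM, with a range from 2500 nM to 17000 nM.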

Compound 4, concentration for 50% growth inhibition: 1240 nM
Compound 4: middle estimate off by 5.2-fold (0.72 log units), on the high side; measured number outside the range, below it.
By their numbers in this assay, from the lowest: compounds 4, 2 and 1 (each within the scatter of the next); then compound 3.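

In this assay, the (4-chloro-3-(trifluoromethyl)phenyl)amino group on the carbonyl carbon gives a step beyond the scatter, with a 7.0-fold lower number from compound 3 to compound 4 (0.85 log units; beyond the scatter), so the penalty seen for compound 3 does not carry over once this amino nitrogen is present. With that nitrogen in place, the change from chloro to trifluoromethyl gives a 1.4-fold lower number from compound 2 to compound 4 (0.14 log units; within the scatter), and adding the chloro to the group of compound 1 along with the nitrogen gives a 2.0-fold lower number from compound 1 to compound 4 (0.30 log units; within the scatter), so both steps leave the three compounds indistinguishable. No measurement on hand explains why the nitrogen matters so much here.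

The compounds shown leave open whether a methylene or an ether oxygen in place of this nitrogen would give the same result. They also leave open how a nitrile or methoxy group on the phenyl ring would fare with either linkage.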